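Removing the chloro from compound 2's chloromethyl group

This account rests on a few compounds, and the source may have more. Where it says the series, first, only, none or still open, it means among the compounds named here.

Measured in an ADME assay (MDM cells, Homo sapiens) for cytotoxicity, read by resazurin assay, with a stated time of 3 days; on this read-out higher numbers stand for weaker inhibition and lower numbers for stronger inhibition:
- compound 1 `O=C(CCl)Nn1c(COc2ccccc2C2=NOC(c3ccc(Cl)cc3Cl)C2)nnc1Sc1ccccc1`: "not determined" (no result reported)
- compound 2 `CSc1nnc(COc2ccccc2C2=NOC(c3ccc(Cl)cc3Cl)C2)n1NC(=O)CCl`: 2.7 ug/mL
- compound 3 `CCCCSc1nnc(COc2ccccc2C2=NOC(c3ccc(Cl)cc3Cl)C2)n1NC(=O)CCl`: 2.8 ug/mL

Among the measured compounds shown here, only two compounds in this small series have numbers. Compound 2 at 2.7 ug/mL lies within the scatter of compound 3 at 2.8 ug/mL, so neither stands apart, and compound 1 offers no number for comparison.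

Compound 4 `CSc1nnc(COc2ccccc2C2=NOC(c3ccc(Cl)cc3Cl)C2)n1NC(C)=O` departs from compound 2 at a single place: hydrogen in place of chloro on a saturated chain carbon bound to a carbonyl carbon. This is hydrogen in place of chloro on a saturated chain carbon bound to a carbonyl carbon, so that chloromethyl becomes methyl.

For the measured compounds named here, the one measured step, a 1.0-fold higher number from compound 2 to compound 3 (0.02 log units; within the scatter), puts propyl in place of hydrogen on a saturated chain carbon bound to a sulfur. That is a different place, so it says nothing directly about the new change. Going by the values given here, all three measured compounds carry the chloromethyl group, and no measurement yet tests its removal. The expectation therefore rests on the structural change alone and remains uncertain.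

In this assay, the expected move is a 2.6-fold higher number from compound 2 to compound 4 (0.41 log units; beyond the scatter), toward a higher number and weaker inhibition. For compound 4 the estimated value is 7 ug/mL, with an expected range from 2.5 ug/mL to 30 ug/mL.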

Compound 4, half-maximal inhibitory concentration: 2.7 ug/mL
Compound 4: middle estimate off by 2.6-fold (0.41 log units), on the high side, and the stated range covers the measured number.
By their numbers in this assay, from the lowest: compounds 2, 4 and 3 (each within the scatter of the next).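

In this assay the first test of this position shows no change at the digits printed from compound 2 to compound 4 (within the scatter), so chloromethyl to methyl on the acetamido side does not separate the pair, and compound 4 stays as active in this read-out as compound 2 without the chloro. Together with a 1.0-fold higher number from compound 2 to compound 3 (0.02 log units; within the scatter), this means that changes at two different places, the saturated chain carbon bound to a carbonyl carbon and the saturated chain carbon bound to a sulfur, have each left the number within the scatter among compounds 2, 3 and 4. Nothing among the data given offers an explanation for this flat result.

What the compounds shown leave open is whether a different group at this place, such as a longer chain, an amine or a carboxylic acid in place of the chloromethyl, would move the number beyond the scatter. As far as these compounds go, it also remains open whether exchanging chloromethyl for methyl would have the same outcome in the setting of compound 3, where a butyl chain rather than a methyl sits on the sulfur.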